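Amide aryl swap at the carbonyl: outlook for compound 4

A few compounds are considered here, and "the series" means these few. Any claim that something is new, unique, unknown or untested is made for them only; others in the source may bear on it.

Measured so far in an assay on CHO cells for displacement of a labelled ligand from adenosine receptor A3 (Homo sapiens), read by scintillation counting; a lower number here means a stronger inhibitor, a higher number a weaker inhibitor:
Compound 1 `O=C(Nc1nc(-c2ccccc2)nc2c1nnn2Cc1ccccc1)c1ccoc1` gives 1640 nM.
Compound 2 `Nc1nc(-c2ccccc2)nc2c1nnn2Cc1ccccc1` gives 4220 nM.
Compound 3 `O=C(Nc1nc(-c2ccccc2)nc2c1nnn2Cc1ccccc1)c1cccc(F)c1` gives 5810 nM.

Compound 3 carries the highest of the three numbers. Its distance to compound 2 is small, a 1.4-fold higher number from compound 2 to compound 3 (0.14 log units; within the scatter), whereas the step of a 3.5-fold higher number from compound 1 to compound 3 (0.55 log units; beyond the scatter) is beyond the scatter, so compound 3 is the weaker of the two amides but not separable from the free amine. Compound 1 stands apart from both: a 2.6-fold higher number from compound 1 to compound 2 (0.41 log units; beyond the scatter).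

Compound 4 `O=C(Nc1nc(-c2ccccc2)nc2c1nnn2Cc1ccccc1)c1ccc(Cl)cc1` is the next member. The change from compound 3 is 4-chlorophenyl in place of 3-fluorophenyl on a carbonyl carbon. Going by the values given here, the one measured step that bears on an aryl exchange at this carbonyl carbon is a 3.5-fold higher number from compound 1 to compound 3 (0.55 log units; beyond the scatter), a modest step. The step of a 1.4-fold higher number from compound 2 to compound 3 (0.14 log units; within the scatter) shows that adding this particular aroyl group to the amine changed little. Among the compounds with values here, no measured pair shows a halogen moved or exchanged within a phenyl ring, so the direction is open. On this basis the expected movement in this assay is small, a 1.3-fold lower number from compound 3 to compound 4 (0.11 log units; within the scatter), likely within the scatter. Compound 4 is estimated at 4500 nM, with a range from 1800 nM to 12000 nM.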

Compound 4, inhibition constant: 3550 nM
The estimate for compound 4 lay 1.3-fold (0.10 log units) above the measured number, and the stated range covers the measured number.
By their numbers in this assay, from the lowest: compound 1; then compounds 4, 2 and 3 (each within the scatter of the next).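

In this assay, going by these compounds alone, the first halogen exchange on the phenyl ring at this carbonyl carbon, 4-chlorophenyl in place of 3-fluorophenyl, does not separate the two aroyl amides (a 1.6-fold lower number from compound 3 to compound 4 (0.21 log units; within the scatter)). The (4-chlorophenyl)carbonyl group also stays unresolved from the free amine (a 1.2-fold lower number from compound 2 to compound 4 (0.08 log units; within the scatter)), while furan-3-yl remains apart from 4-chlorophenyl as well as from 3-fluorophenyl (a 2.2-fold higher number from compound 1 to compound 4 (0.34 log units; beyond the scatter)), so among the amides shown, only compound 1 lies beyond the scatter of the free amine. No evidence at hand accounts for these steps.

From the compounds shown here alone, the exchange from compound 3 to compound 4 alters both the halogen and its place on the ring, so the two changes cannot be told apart, and any effect of either one alone remains open. Going by these compounds, it is also open whether the separation of compound 1 is particular to furan-3-yl or extends to other groups on this carbonyl carbon, such as thiophen-3-yl, 4-methoxyphenyl or a short alkyl chain like methyl.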